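One Enantiomer of Compound 2: Expected Oral Bioavailability

This account rests on a few compounds, and the source may have more. Where it says the series, first, only, none or still open, it means among the compounds named here.

Compound 1 `CC(C)(C)CCC1(NCc2ccc3ccccc3c2)C(=O)C(C2=NS(=O)(=O)c3cc(NS(C)(=O)=O)ccc3N2)=C(O)c2ccccc21`: 28.1%
Compound 2 `Cc1cccc(C)c1CNC1(CCC(C)(C)C)C(=O)C(C2=NS(=O)(=O)c3cc(NS(C)(=O)=O)ccc3N2)=C(O)c2ccccc21`: 53.7%

In an in vivo ADME assay on the whole organism (strain Sprague-Dawley) for pharmacokinetics, with Rattus norvegicus as the target, at a dose of 5 mg/kg by the oral route (on this read-out higher numbers stand for higher oral bioavailability and lower numbers for lower oral bioavailability), compound 2 gives 53.7%, the highest of the two numbers measured. Within the data shown here, the only other compound, compound 1, gives 28.1%. Among the measured compounds shown here, the single measured step, a number 25.6 percentage points higher from compound 1 to compound 2 (beyond the scatter), came with the exchange of the group on the saturated chain carbon bound to the amine nitrogen, so it tells nothing about what a stereochemical assignment does.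

Compound 3 `Cc1cccc(C)c1CN[C@]1(CCC(C)(C)C)C(=O)C(C2=NS(=O)(=O)c3cc(NS(C)(=O)=O)ccc3N2)=C(O)c2ccccc21` keeps every atom and bond of compound 2: the two compounds have the same atoms and bonds; at least one stereo element is drawn with a configuration in one of them and without one in the other: 1 of 1 stereo elements differ; a stereocentre at a saturated ring carbon is drawn without a configuration in compound 2 and S in compound 3. Compound 3 is thus one defined form of the material that compound 2 represents. For the measured compounds named here, no measured step isolates such a change, so there is no basis for expecting a step beyond the scatter in this assay; the estimated step is a number 0.3 percentage points higher from compound 2 to compound 3 (within the scatter). For compound 3 the expected value is 54%, within an estimated range from 35% to 73%.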

Compound 3, oral bioavailability: 55.9%
Compound 3: middle estimate off by 1.9 percentage points, on the low side; measured number inside the range.
By their numbers in this assay, from the lowest: compound 1; then compounds 2 and 3 (each within the scatter of the next).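

In this assay the change at the saturated ring carbon gives a number 2.2 percentage points higher from compound 2 to compound 3 (within the scatter), so the two compounds cannot be told apart on this read-out. Among these compounds, the earlier step showed only that exchanging a group on the amine side can move oral bioavailability beyond the scatter; this pair adds that the S form at this carbon keeps the level of the form drawn without a configuration. The comparison is therefore one of a defined drawing with an undefined one, not of two opposite configurations, because of one fact: the fact that one of compounds 2 and 3 is drawn with a defined configuration and the other without, at the place where they differ

The compounds shown leave open how the R form at this carbon would behave in this assay. They also leave open what a carboxylic acid or a longer chain on that saturated ring carbon would do to oral bioavailability.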